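Aminohexyl in place of phenylethyl on the core amine

The compounds below may be only part of what the source reports. "The series", "measured", "known", "first", "only" and "open" are said of these compounds alone.

Measured so far:
compound 1 `C[C@@H](Nc1c(C(=O)NCc2ccc(F)cc2)nc(Br)c2cccnc12)c1ccccc1`, > 20000 nM
compound 2 `CS(=O)(=O)NCCCCCCN(c1nc(C(=O)NCc2ccc(F)cc2)c(O)c2ncccc12)S(C)(=O)=O`, 3000 nM
compound 3 `COc1ccc(CNC(=O)c2nc(Br)c3cccnc3c2N[C@H]2CC[C@H](N)CC2)cc1`, 3000 nM

In a functional assay on HCT-116 cells (Homo sapiens) for cytotoxicity, read by MTT assay, with a stated time of 72 h (on this read-out higher numbers stand for weaker inhibition and lower numbers for stronger inhibition), compound 1 gives > 20000 nM, which is a limit of the assay and not a number (the limit of > 20000 nM in this assay, at which 1 of the 3 values shown sits). Compound 2 gives 3000 nM and compound 3 gives 3000 nM, the two within the usual scatter of each other. Compound 4 `NCCCCCCNc1c(C(=O)NCc2ccc(F)cc2)nc(Br)c2cccnc12` is not yet measured; it differs from compound 1 as follows: 6-aminohexyl in place of 1-phenylethyl on a nitrogen on an aromatic ring. With compound 1 at a limit, only the direction of the step is expected, toward stronger inhibition, in line with the numbers for compounds 2 and 3. The step of an at least 4.0-fold lower number from compound 1 to compound 4 (0.60 log units; beyond the scatter) is the estimate, because compound 3 gives 3000 nM. Compound 4 is thus expected at 5000 nM, between 1500 nM and 20000 nM.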

Compound 4, half-maximal inhibitory concentration: 7000 nM
For compound 4 the middle estimate is 1.4-fold (0.15 log units) below the measured one; low and high end bracket the measured number.
By their numbers in this assay, from the lowest: compounds 2 and 3 (each within the scatter of the next); then compound 4. At a limit, above all of these: compound 1.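

In this assay, going by these compounds alone, the change to 6-aminohexyl on a nitrogen on an aromatic ring gives an at least 2.8-fold lower number from compound 1 to compound 4 (0.45 log units; beyond the scatter) and is the first comparison at this position that differs in one place only. A measurable number here therefore does not depend on the aromatic ring or the defined stereocentre of 1-phenylethyl. Compound 1 gives > 20000 nM as a limit of the assay and not a number: the limit of > 20000 nM in this assay, at which 1 of the 4 values shown sits.

Going by these compounds, whether the amine or the chain carries the step stays open. A plain hexyl, aminobutyl or aminooctyl group on the same nitrogen would separate the two.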